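This account rests on a few compounds, and the source may have more. Where it says the series, first, only, none or still open, it means among the compounds named here.

In a functional assay on SK-MEL-2 cells (Homo sapiens) (on this read-out higher numbers stand for an effect only at larger amounts of compound and lower numbers for an effect already at smaller amounts), compound 1 `Oc1nc(-c2cccc(F)c2)nc2ccccc12` gives > 20 ug/mL, which is a limit of the assay and not a number. Compound 2 `COc1cc2nc(-c3ccccc3F)nc(O)c2cc1OC` gives < 5 ug/mL, also a limit and the lower of the two readings. Compound 3 `COc1cc2nc(-c3cccc(F)c3)nc(O)c2cc1OC` keeps the core of compound 2 but carries 3-fluorophenyl in place of 2-fluorophenyl on an aromatic carbon. Going by the values given here, the same 3-fluorophenyl sits on compound 1, but that compound also has a different core, so no measured pair isolates this change. The expected step, a step that the limit leaves unreadable from compound 2 to compound 3, goes in no firm direction and is not expected to exceed the usual scatter. Compound 3 is estimated at 4 ug/mL, within a range from 1 ug/mL to 15 ug/mL.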

Compound 3, concentration for half-maximal effect: > 20 ug/mL
Compound 3 ended at the assay's limit; the forecaster's own chance of this, stated with the estimate: 35%; at least 5.0-fold (0.69 log units) between middle value and limit.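

In this assay, 3-fluorophenyl in place of 2-fluorophenyl gives an at least 4.0-fold higher number from compound 2 to compound 3 (0.60 log units; beyond the scatter). This is the first pair shown that differs in one place, so with the shared core unchanged, the fluorine's place on the phenyl ring alone separates the two readings. The step is only a bound, because compound 2 stands at a limit: the limit of < 5 ug/mL in this assay, at which 1 of the 3 values shown sits.

On these data alone, compound 3 also stands at a limit, so the true size of the step stays open: the limit of > 20 ug/mL in this assay, at which 2 of the 3 values shown sit. Also open is whether a chlorine atom or an amine on that phenyl ring would keep the reading of compound 2.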